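The compounds below may be only part of what the source reports. "The series", "measured", "known", "first", "only" and "open" are said of these compounds alone.

Working notes on a small set of quinazolinone-type inhibitors tested in an assay on isolated protein for inhibition of DNA topoisomerase 1 (Homo sapiens), with a stated time of 30 min, tested at 100 uM; a lower number here means a weaker effect, a higher number a stronger effect of the compound at the concentration tested. Compound 1 `CCN(CC)c1ccc2nc(-c3cccc4ccccc34)[nH]c(=O)c2c1` gives 90.4% in this assay. Compound 2 `Cc1ccc2c(=O)[nH]c(-c3cccc(F)c3)nc2c1` gives 77.5%. Compound 3 `Cc1ccc2nc(-c3ccccc3C(F)(F)F)[nH]c(=O)c2c1` gives 72%, the lowest of the three numbers shown. Its nearest neighbour on the numbers is compound 2, whose value sits within the scatter of that of compound 3, so no order between those two can be read. Compound 1 stands furthest away, beyond the scatter, so compound 1 is the only one of the three whose number is clearly higher than that of compound 3.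

The next compound, compound 4 `Cc1ccc2nc(-c3ccccc3N(C)C)[nH]c(=O)c2c1`, is not yet measured. It differs from compound 3 in one place: dimethylamino in place of trifluoromethyl on an aromatic carbon. Within the data shown here, no pair among the measured compounds shows this same exchange, so there is no measured step to lean on; the only guidance is that compounds 2 and 3, which carry different groups on the pendant ring, land within the scatter of each other.

Given that, the expectation for the step in this assay is none beyond the scatter, estimated as a number 2 percentage points lower from compound 3 to compound 4 (within the scatter). Compound 4 is therefore estimated at 70%, with a range from 50% to 88%.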

Compound 4, a percentage reported as inhibition, at one concentration (the size of the read-out at that concentration, not a potency): 82.9%
Beside the measured number, compound 4's estimate is 12.9 percentage points below it, and the stated range covers the measured number.
By their numbers in this assay, from the lowest: compounds 3, 2, 4 and 1 (each within the scatter of the next, the first and the last beyond it).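

In this assay, among these compounds, dimethylamino in place of trifluoromethyl on an aromatic carbon, ortho to a large group, gives a number 10.9 percentage points higher from compound 3 to compound 4 (beyond the scatter) and so provides the first single-place step. This place on the six-membered aromatic ring of carbon only is therefore not indifferent to the group it carries, although the step is modest and rests on one pair, read at one concentration, which gives the size of the read-out and not a potency. No measurement shown here bears on why the exchange changes the number.

Among the compounds shown here, the single pair cannot separate what the entering dimethylamino contributes from what the departing trifluoromethyl removes, and a primary amine, a methoxy group or a carboxylic acid at the same place would help to tell these apart. Also open is whether the exchange gives a step of similar size on a different core or at another place on the ring, since no second pair with this change is shown.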